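This account rests on a few compounds, and the source may have more. Where it says the series, first, only, none or still open, it means among the compounds named here.

Compound 1 `CC(C)n1nc(-c2ccccc2)c(-c2ccccc2)cc1=O` gives 152000 nM in an assay on microsomes from liver for inhibition of sterol O-acyltransferase 1 (Rattus norvegicus); a higher number here means a weaker inhibitor, a lower number a stronger inhibitor.
Compound 2 `CCCCCC(=O)Nc1cc(-c2ccccc2)c(-c2ccccc2)nn1` gives only a limit of the assay, > 300000 nM, in this assay.
Compound 3 `CCCCCCCCC[S+]([O-])c1cc(-c2ccccc2)c(-c2ccccc2)nn1` gives 87000 nM in this assay.

Compound 2 thus stands at the edge of what this assay can report, a limit where one of the three values sits (the limit of > 300000 nM in this assay, at which 1 of the 3 values shown sits). Compound 4 `O=C(O)CCCCCSc1cc(-c2ccccc2)c(-c2ccccc2)nn1` has not been measured. It differs from compound 2 in one place: (5-carboxypentyl)sulfanyl in place of (pentylcarbonyl)amino on an aromatic carbon. Going by the values given here, no step between measured compounds is available to guide this change. Since compound 3 gives 87000 nM, a number rather than a limit, compound 4 is expected to return a number as well, a step toward stronger inhibition an at least 3.0-fold lower number from compound 2 to compound 4 (0.47 log units; beyond the scatter) that should exceed the usual scatter. The estimate for compound 4 is 100000 nM, between 30000 nM and 300000 nM.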

Compound 4, half-maximal inhibitory concentration: > 300000 nM
Compound 4: a limit, no number; the forecaster's own chance of this, stated with the estimate: 30%; at least 3.0-fold (0.47 log units) between middle value and limit.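

Compound 2 and compound 4 each give only a limit, so no step between them can be read: the limit of > 300000 nM in this assay, at which 2 of the 4 values shown sit.

The compounds shown leave open whether (5-carboxypentyl)sulfanyl and (pentylcarbonyl)amino differ at all in this assay.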